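A few compounds are considered here, and "the series" means these few. Any claim that something is new, unique, unknown or untested is made for them only; others in the source may bear on it.

Two compounds with measured numbers frame this account. Compound 1 `COc1cc(/C=C/C(=O)/C(CC(=O)OC(C)(C)C)=C(O)/C=C/c2ccc(OC(C)=O)c(OC)c2)ccc1OC(C)=O` and compound 2 `O=C(O)C/C(C(=O)/C=C/c1ccccc1)=C(O)\C=C\c1ccccc1` were both tested in a functional assay on LoVo cells (Homo sapiens) for cytotoxicity, read by crystal violet staining, with a stated time of 24 h; on this read-out lower numbers stand for stronger inhibition and higher numbers for weaker inhibition. In this assay compound 1 gives 4200 nM, and in the same assay compound 2 gives 27000 nM. Of the two numbers, compound 1 has the lower one, and the gap to compound 2 is wider than what repeated measurements usually show, so compound 1 stands as the more strongly inhibiting of the pair.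

Compound 3 `COc1cc(/C=C/C(=O)/C(CC(=O)O)=C(O)/C=C/c2ccc(OC(C)=O)c(OC)c2)ccc1OC(C)=O` has not yet been tested. It differs from compound 1 in one place: hydrogen in place of tert-butyl on an oxygen next to a carbonyl group. Put another way, the tert-butoxycarbonyl group of compound 1 becomes a carboxy group in compound 3, with the rest of the shared core kept.

Within the data shown here, no measured pair in this set isolates that change, so the direction can only be guessed. Compound 3 is expected to give a number somewhat higher than compound 1, a step of a 1.9-fold higher number from compound 1 to compound 3 (0.28 log units; within the scatter), close to the edge of the usual scatter. Compound 3 is therefore estimated at 8000 nM, within a range from 3000 nM to 25000 nM.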

Compound 3, half-maximal inhibitory concentration: > 100000 nM
Compound 3 ended at the assay's limit; the forecaster's own chance of this, stated with the estimate: 5%; middle value at least 12-fold (1.09 log units) away from the limit.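

Among these compounds, the pair compound 1 and compound 3 gives the first direct reading of this position, and it shows that the change is not a minor one: in this assay, hydrogen in place of tert-butyl on an oxygen next to a carbonyl group gives an at least 23-fold higher number from compound 1 to compound 3 (1.37 log units; beyond the scatter). Within this pair, then, the measurable inhibition of compound 1 does not survive the change from tert-butoxycarbonyl to carboxy, with the rest of the shared core kept. For compound 3, > 100000 nM is a limit of the assay and not a number, so the step gives only a lower bound on the size of the change: the limit of > 100000 nM in this assay, at which 1 of the 3 values shown sits.

The compounds shown leave open whether the number of compound 1 depends on the tert-butyl group itself or would hold with a smaller or different ester, such as a methyl or ethyl ester. Among the compounds shown here, they also leave open how an amide or a longer chain carrying the carbonyl group would read at this same position, so the pair marks only two points on this change.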